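Indole hydrazones on PC-3 cells: a methoxy-to-chloro swap

The source may hold more compounds than are shown below. What is called first, only, known or untested is meant among the compounds shown, and "the series" means these compounds.

The measured compounds are these: compound 1, `COc1ccc(Cn2cc(/C=N\NC(=O)c3c[nH]c4ccccc34)c3cc(OC)ccc32)cc1`, which in a functional assay on PC-3 cells (Homo sapiens) for cytotoxicity (on this read-out lower numbers stand for stronger inhibition and higher numbers for weaker inhibition), gives 13600 nM; compound 2, `COc1ccc2c(c1)c(/C=N\NC(=O)c1c[nH]c3ccccc13)cn2Cc1ccc(Cl)cc1`, which in this assay gives 30300 nM; and compound 3, `COc1ccc(Cn2cc(/C=N\NC(=O)c3c[nH]c4ccc(Br)cc34)c3ccc(F)cc32)cc1`, which in this assay gives 21800 nM.

Compound 1 and compound 2 share their core and differ in one place: chloro in place of methoxy on an aromatic carbon. This change made a step of a 2.2-fold higher number from compound 1 to compound 2 (0.35 log units; beyond the scatter). Compound 3 stands second highest of the three numbers; its distance from compound 2 and from compound 1 both lie within the scatter, so no order among these three is claimed from those two gaps. How the core of compound 3 differs from the core of compound 1 is not broken down here.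

Compound 4, `O=C(N/N=C\c1cn(Cc2ccc(Cl)cc2)c2cc(F)ccc12)c1c[nH]c2ccc(Br)cc12`, has not yet been measured in this assay. It differs from compound 3 in one place: chloro in place of methoxy on an aromatic carbon. The place lines are the same word for word, so this is the same change that was made from compound 1 to compound 2, occurring twice among the compounds shown. Because the change from compound 1 to compound 2 gave a 2.2-fold higher number from compound 1 to compound 2 (0.35 log units; beyond the scatter), a step of similar size and direction is expected from compound 3 to compound 4, namely a 2.1-fold higher number from compound 3 to compound 4 (0.31 log units; beyond the scatter), though it rests on a single earlier pair and on a different core. Compound 4 is therefore estimated at 45000 nM, with a plausible range from 18000 nM to 110000 nM.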

Compound 4, half-maximal inhibitory concentration: 12400 nM
Estimate against measurement, compound 4: 3.6-fold (0.56 log units) above; measured number below the stated range.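

In this assay, carrying the swap of 4-methoxybenzyl to 4-chlorobenzyl onto a second core gave a 1.8-fold lower number from compound 3 to compound 4 (0.25 log units; within the scatter), so on that core the effect of the change cannot be told apart from the scatter of repeated measurements, whereas on the first core the step lay beyond it. For the compounds shown here, the change therefore did not carry over as a fixed step, and the higher number seen on the first core cannot be taken as a general result of this swap: the same change on two cores in this assay, a 2.2-fold higher number (0.35 log units; beyond the scatter) from compound 1 to compound 2 and a 1.8-fold lower number (0.25 log units; within the scatter) from compound 3 to compound 4, 3.9-fold (0.59 log units) apart, beyond the scatter of two such steps With only one pair on each core, this does not show which feature of the two cores sets the steps apart, nor whether the swap would follow either step on a further core.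

The compounds shown leave open whether the group at this place has a consistent bearing on the read-out on any one core, since each core offers only a single comparison. Also open, on these data alone, is how an amine or a carboxylic acid at the same aromatic carbon would read in this assay on these two cores.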